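The compounds below may be only part of what the source reports. "The series", "measured", "known", "first", "only" and "open" are said of these compounds alone.

Compound 1 `CC1(C)C/C(=N\NC(N)=O)c2cc(O)ccc2O1` and compound 2 `CCC1(C)C/C(=N\NC(N)=O)c2cc(O)ccc2O1` share one core and differ only by methyl in place of hydrogen on a saturated chain carbon bound to a saturated ring carbon. In a functional assay on MCF7 cells (Homo sapiens) for inhibition, with a stated time of 96 h (on this read-out higher numbers stand for weaker inhibition and lower numbers for stronger inhibition), compound 1 gives 150000 nM, while compound 2 gives 70000 nM, a step of a 2.1-fold lower number from compound 1 to compound 2 (0.33 log units; beyond the scatter). Compound 3 `CC1(C)C/C(=N\NC(N)=S)c2cc(O)ccc2O1` rests on a second core: relative to compound 1 it carries a group of 3 heavy atoms (1 carbon, 1 nitrogen, 1 sulfur; no ring) in place of a group of 3 heavy atoms (1 carbon, 1 nitrogen, 1 oxygen; no ring), on an amine nitrogen, and in this assay compound 3 gives 140000 nM, a step of a 1.1-fold lower number from compound 1 to compound 3 (0.03 log units; within the scatter). Compound 4 `CCC1(C)C/C(=N\NC(N)=S)c2cc(O)ccc2O1` has not been measured yet; it stands to compound 3 exactly as compound 2 stands to compound 1, through (methyl in place of hydrogen on a saturated chain carbon bound to a saturated ring carbon), the same change at the same place. Carrying that change over to the second core, compound 4 is expected to show a 2.0-fold lower number from compound 3 to compound 4 (0.30 log units; within the scatter) in this assay, an expectation resting on only one earlier step, a 2.1-fold lower number from compound 1 to compound 2 (0.33 log units; beyond the scatter). Compound 4 is therefore estimated at 70000 nM, likely between 35000 nM and 140000 nM.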

Compound 4, half-maximal inhibitory concentration: 60000 nM
The estimate for compound 4 lay 1.2-fold (0.07 log units) above the measured number; measured number inside the range.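

In this assay, methyl in place of hydrogen gives a 2.3-fold lower number from compound 3 to compound 4 (0.37 log units; beyond the scatter) on the second core, much as it did on the first: the same change on two cores in this assay, a 2.1-fold lower number (0.33 log units; beyond the scatter) from compound 1 to compound 2 and a 2.3-fold lower number (0.37 log units; beyond the scatter) from compound 3 to compound 4, 1.1-fold (0.04 log units) apart, within the scatter of two such steps. Seen from the other side, the sulfur-bearing group in place of the oxygen-bearing group gives a 1.2-fold lower number from compound 2 to compound 4 (0.07 log units; within the scatter) and stays within the scatter on both cores: the same change on two cores in this assay, a 1.1-fold lower number (0.03 log units; within the scatter) from compound 1 to compound 3 and a 1.2-fold lower number (0.07 log units; within the scatter) from compound 2 to compound 4, 1.1-fold (0.04 log units) apart, within the scatter of two such steps. These two cores do show the methyl step carrying over with its size kept, but they do not show that it would do so on any other core, nor why the numbers move.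

The compounds shown leave open whether a longer chain than ethyl at the same place would continue the step. They also leave open how an amine at that place would behave.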